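The source may hold more compounds than are shown below. What is called first, only, known or untested is meant among the compounds shown, and "the series" means these compounds.

Measured so far:
- compound 1 `CCOc1ccc(Br)cc1-c1cc(Nc2ccc(C(C)=O)cc2)nc(N)n1`: 90 nM
- compound 2 `Cc1ccc(F)cc1-c1cc(Nc2ccc(Cl)cc2)nc(N)n1`: > 1000 nM
- compound 3 `Cc1ccc(Cl)cc1-c1cc(Nc2cccc(Br)c2)nc(N)n1`: 400 nM

All three compounds were tested in a functional assay on DU-145 cells (Homo sapiens) for inhibition; a lower number here means a stronger inhibitor, a higher number a weaker inhibitor. Compound 2 is reported only as > 1000 nM, which is a limit of the assay and not a number. For compound 2, this is the limit of > 1000 nM in this assay, at which 1 of the 3 values shown sits.

Compound 4 `Cc1ccc(Br)cc1-c1cc(Nc2ccc(Cl)cc2)nc(N)n1` keeps everything in compound 2 except one group, with bromo in place of fluoro on an aromatic carbon, para to a methyl group (bromo in place of fluoro on an aromatic carbon). For the measured compounds named here, no measured pair shows this swap alone, so the expectation rests on indirect evidence. Compound 3, with chloro at that place, gives 400 nM. Compound 1, with bromo there, gives 90 nM. Both also differ from compound 2 elsewhere, so they offer only a loose guide. On that basis, a moderate gain in this assay is expected. The estimated change is an at least 2.5-fold lower number from compound 2 to compound 4 (0.39 log units; beyond the scatter). Compound 4 is expected to give about 400 nM, with an estimated range from 150 nM to 1000 nM.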

Compound 4, half-maximal inhibitory concentration: 100 nM
Compound 4: the middle estimate sits 4.0-fold (0.60 log units) above what was measured; measured number below the stated range.
By their numbers in this assay, from the lowest: compounds 1 and 4 (each within the scatter of the next); then compound 3. At a limit, above all of these: compound 2.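

In this assay, for the compounds shown here, this is the first pair of compounds that differ in one place only, and bromo in place of fluoro on the aromatic carbon para to a methyl group gives an at least 10-fold lower number from compound 2 to compound 4 (1.00 log units; beyond the scatter). Going by these compounds alone, compound 1 and compound 3 each differ from compound 2 in more than one place, so only this pair ties the gain to this single change. The true size of the step stays unknown because compound 2 is a limit and not a number: the limit of > 1000 nM in this assay, at which 1 of the 4 values shown sits.

As far as these compounds go, it remains open how a methoxy group, a nitrile or an amine at this place would compare with bromo, with the rest of compound 4 unchanged. From the compounds shown here alone, it is also open whether the same swap would give a similar gain with different groups elsewhere in the molecule.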